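Replacing the 4-hydroxycyclohexyl group of compound 1

This account rests on a few compounds, and the source may have more. Where it says the series, first, only, none or still open, it means among the compounds named here.

In an ADME assay on S9 fraction from liver (Homo sapiens) for metabolic stability, with a stated time of 1 h (on this read-out lower numbers stand for a less stable compound and higher numbers for a more stable compound), compound 1 (`N#Cc1cnc(NCc2cnccc2C(F)(F)F)cc1N[C@H]1CC[C@H](O)CC1`) gives 30%. For the measured compounds named here, this is the lower of the only two numbers available, and compound 2 (`N#Cc1cnc(NCc2ccccc2C(F)(F)F)cc1N[C@H]1C[C@@H](C(N)=O)C1`) gives 86%, a gap well beyond the usual scatter. The next compound to be tested is compound 3 (`CNC(=O)[C@H]1CC[C@@H](Nc2cc(NCc3cnccc3C(F)(F)F)ncc2C#N)CC1`), which has no reading yet. It departs from compound 1 at one place, with 4-(methylcarbamoyl)cyclohexyl in place of 4-hydroxycyclohexyl on a nitrogen on an aromatic ring.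

Going by the values given here, no two measured compounds differ in only one place, so the data offer no direct precedent for this change, and any forecast is uncertain. Two readings still frame it: compound 1 at 30% leaves ample room to rise, and compound 2 at 86% shows that much higher numbers occur in this small set. A rise beyond the scatter is therefore expected, with an estimated a number 25 percentage points higher from compound 1 to compound 3 (beyond the scatter). The expected value for compound 3 is 55%, with an estimated range from 30% to 82%.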

Compound 3, percent of the compound remaining: 71%
For compound 3 the middle estimate is 16 percentage points below the measured one, within the range that was stated.
By their numbers in this assay, from the lowest: compound 1; then compound 3; then compound 2.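

For the compounds shown here, at the position on a nitrogen on an aromatic ring, 4-(methylcarbamoyl)cyclohexyl in place of 4-hydroxycyclohexyl gives the first comparison in this set that changes one place only: in this assay the change is a number 41 percentage points higher from compound 1 to compound 3 (beyond the scatter). With the rest of the core of compound 1 unchanged, this shows that the group at this one position can by itself shift the percent of compound remaining by a large amount, which the earlier pair of compounds, differing in more than one place, could not show. No measurement given here bears on why the number rises.

The compounds shown leave open which part of the 4-(methylcarbamoyl)cyclohexyl group goes with the rise, and a carboxylic acid or an amine on the same cyclohexyl ring would help to separate the carbonyl, the amide hydrogen and the methyl from one another. They also leave open whether the same replacement would give a step of similar size on the core of compound 2.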